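Replacing the ester arm by a pyrrolidine amide in a cytotoxicity series

The compounds below may be only part of what the source reports. "The series", "measured", "known", "first", "only" and "open" are said of these compounds alone.

Compounds measured so far:
compound 1 `Cc1cc(C)c(Oc2cc(Nc3ccc(C#N)cc3)ncc2C(=O)NCc2cn(Cc3cccc([N+](=O)[O-])c3)nn2)c(C)c1`: >= 156000 nM
compound 2 `Cc1cc(C)c(Oc2cc(Nc3ccc(C#N)cc3)ncc2C(=O)NCc2cn(CC(=O)N3CCOCC3)nn2)c(C)c1`: 181000 nM
compound 3 `CCOC(=O)CCn1cc(CNC(=O)c2cnc(Nc3ccc(C#N)cc3)cc2Oc2c(C)cc(C)cc2C)nn1`: 21500 nM

In an ADME assay on MT4 cells (Homo sapiens) for cytotoxicity, read by MTT assay, with a stated time of 5 days (on this read-out higher numbers stand for lower toxicity in this test and lower numbers for higher toxicity in this test), compound 1 gives only a limit, >= 156000 nM. Compound 2 gives 181000 nM and compound 3 gives 21500 nM, the lowest of the two numbers shown. The steps run an at least 7.2-fold lower number from compound 1 to compound 3 (0.86 log units; beyond the scatter) and an 8.4-fold lower number from compound 2 to compound 3 (0.93 log units; beyond the scatter). Compound 4 `Cc1cc(C)c(Oc2cc(Nc3ccc(C#N)cc3)ncc2C(=O)NCc2cn(CC(=O)N3CCCC3)nn2)c(C)c1` differs from compound 3 by (pyrrolidin-1-yl)carbonyl in place of (ethoxycarbonyl)methyl on a saturated chain carbon bound to an aromatic nitrogen. For the measured compounds named here, the change most like it is the one from compound 2 to compound 3 read backwards, where an amide on that carbon gave the higher number, so the number for compound 4 is expected to rise, estimated as a 4.7-fold higher number from compound 3 to compound 4 (0.67 log units; beyond the scatter). Compound 4 is therefore estimated at 100000 nM, between 30000 nM and 250000 nM.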

Compound 4, half-maximal cytotoxic concentration: 58100 nM
Compound 4: middle estimate off by 1.7-fold (0.24 log units), on the high side; low and high end bracket the measured number.
By their numbers in this assay, from the lowest: compound 3; then compound 4; then compound 2.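

In this assay, the gain over the ester does not depend on morpholin-4-yl, since a second amide also gives a 2.7-fold higher number from compound 3 to compound 4 (0.43 log units; beyond the scatter). The amides are not interchangeable at this position, however: pyrrolidin-1-yl in place of morpholin-4-yl gives a 3.1-fold lower number from compound 2 to compound 4 (0.49 log units; beyond the scatter). Compound 1 gives only a limit, which leaves an at least 2.6-fold lower number from compound 1 to compound 4 (0.42 log units; beyond the scatter): the limit of >= 156000 nM in this assay, at which 1 of the 4 values shown sits.

As far as these compounds go, what a piperidin-1-yl amide or a carboxylic acid would give on that saturated chain carbon stays open. So does how much of the ester-to-amide step belongs to the change from 2-(ethoxycarbonyl)ethyl to ((pyrrolidin-1-yl)carbonyl)methyl as a chain rather than to the amide itself.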